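The Same Aryl Swap on the Other Stereoisomer

The source may report more compounds than this note shows. Statements on the series, on what has been measured and on what is new or still open speak of the compounds shown alone.

Compound 3 `CC[C@H](C)[C@H]1C(=O)N[C@H](Cc2ccc(O)c(Br)c2)C(=O)N[C@@H](C(C)(C)O)C(=O)O[C@H](c2ccccc2)[C@H](C)/C=C/C=C(\C)[C@H](OC)C[C@H]2O[C@]2(C)C(=O)N1C` has the same atoms and bonds as compound 2 `CC[C@H](C)[C@H]1C(=O)N[C@H](Cc2ccc(O)c(Br)c2)C(=O)N[C@@H](C(C)(C)O)C(=O)O[C@H](c2ccccc2)[C@H](C)/C=C/C=C(\C)[C@H](OC)C[C@@H]2O[C@@]2(C)C(=O)N1C` and differs from it only in configuration as drawn. In a functional assay on HepG2 cells (Homo sapiens) for antiproliferative activity (a lower number here means a stronger inhibitor, a higher number a weaker inhibitor), compound 2 gives 2.98 nM. Compound 3 gives only a limit of the assay, > 200 nM, and no number. That makes the step of an at least 67-fold higher number from compound 2 to compound 3 (1.82 log units; beyond the scatter), a large loss of potency, and what can be said about it rests on the fact that compounds 2 and 3 differ only in the configuration as drawn and (the limit of > 200 nM in this assay, at which 1 of the 3 values shown sits). Compound 1 `CC[C@H](C)[C@H]1C(=O)N[C@H](Cc2cc(Cl)c(O)c(Cl)c2)C(=O)N[C@@H](C(C)(C)O)C(=O)O[C@H](c2ccccc2)[C@H](C)/C=C/C=C(\C)[C@H](OC)C[C@@H]2O[C@@]2(C)C(=O)N1C` carries 3,5-dichloro-4-hydroxyphenyl where compound 2 carries 3-bromo-4-hydroxyphenyl, and in this assay compound 1 gives 3.36 nM, so that a 1.1-fold lower number from compound 1 to compound 2 (0.05 log units; within the scatter). Compound 4 `CC[C@H](C)[C@H]1C(=O)N[C@H](Cc2cc(Cl)c(O)c(Cl)c2)C(=O)N[C@@H](C(C)(C)O)C(=O)O[C@H](c2ccccc2)[C@H](C)/C=C/C=C(\C)[C@H](OC)C[C@H]2O[C@]2(C)C(=O)N1C` applies that exchange to compound 3: 3,5-dichloro-4-hydroxyphenyl in place of 3-bromo-4-hydroxyphenyl on a saturated chain carbon bound to a saturated ring carbon. For the measured compounds named here, the one measured step that bears on this change is a 1.1-fold lower number from compound 1 to compound 2 (0.05 log units; within the scatter), which ran in the opposite direction and stayed within the scatter. The step is therefore expected to be a step that the limit leaves unreadable from compound 3 to compound 4, nothing beyond the scatter in either direction. Because compound 3 stands only at the limit > 200 nM, compound 4 is expected to stand at that limit as well. As a number, compound 4 is estimated at 600 nM, with a range from 200 nM to 3000 nM.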

Compound 4, half-maximal inhibitory concentration: > 200 nM
Compound 4: a limit, no number; the forecaster's own chance of this, stated with the estimate: 85%; the middle value does not contradict the limit.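

In this assay, the loss of potency on changing the drawn configuration now appears with a second aryl group and not only with 3-bromo-4-hydroxyphenyl: the 3,5-dichloro-4-hydroxyphenyl pair shows an at least 59-fold higher number from compound 1 to compound 4 (1.77 log units; beyond the scatter), and the 3-bromo-4-hydroxyphenyl pair shows an at least 67-fold higher number from compound 2 to compound 3 (1.82 log units; beyond the scatter). This second large step can be tied to configuration alone, with no other structural change involved: the fact that compounds 1 and 4 differ only in the configuration as drawn The exchange of 3-bromo-4-hydroxyphenyl for 3,5-dichloro-4-hydroxyphenyl cannot be read on this stereoisomer, as compound 3 and compound 4 both stand at a limit of the assay and neither gives a number.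

As far as these compounds go, how much potency compound 3 and compound 4 retain therefore stays open, as does the question of whether their two aryl groups differ at all on this stereoisomer. For the compounds shown here, also open is how a compound with only one of the two ring stereocentres changed would read, and whether a plain phenyl or a 4-aminophenyl, on a saturated chain carbon bound to a saturated ring carbon, would match compound 1 and compound 2.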